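Notes on the carbonyl substituent step from compound 3

A few compounds are considered here, and "the series" means these few. Any claim that something is new, unique, unknown or untested is made for them only; others in the source may bear on it.

Measured so far in a functional assay on CHO-K1 cells for agonist activity at Glucose-dependent insulinotropic receptor (Homo sapiens), read by a luciferase reporter, with a stated time of 5 h; a higher number here means that more compound is needed for the effect, a lower number that less compound is needed:
- compound 1 `CC(C)OC(=O)N1CCC(Oc2cccc3c2CCN3c2ccc(S(C)(=O)=O)cc2)CC1` gives 501 nM
- compound 2 `CC(C)OC(=O)N1CCC(Oc2ncnc3c2CCN3c2ccc(-c3cccn3C)cc2F)CC1` gives 158 nM
- compound 3 `CCCOC(=O)N1CCC(Oc2ncnc3c2CCN3c2ccc(S(C)(=O)=O)cc2F)CC1` gives 79.4 nM

Compound 3 shows the lowest of the three numbers in this assay. Its gap to compound 2 lies within the scatter, so the two are not separable on these data; its gap to compound 1 lies beyond the scatter. No two of the measured compounds differ in a single place, so no single step can be read off from them.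

Compound 4 `CC(C)SC(=O)N1CCC(Oc2ncnc3c2CCN3c2ccc(S(C)(=O)=O)cc2F)CC1` is not yet measured. Against compound 3 the change is isopropylsulfanyl in place of propoxy on a carbonyl carbon. Both groups carry the same count of heavy atoms, no ring, no donor and one acceptor, and the change sits away from the fused core and the aryl group that the measured compounds vary. Within the data shown here, nothing among the measured compounds bears on this position, so the step is expected to be small, with no direction beyond the scatter.

Compound 4 is therefore estimated at 110 nM, in the range 40 nM to 300 nM, which means an expected step of a 1.4-fold higher number from compound 3 to compound 4 (0.14 log units; within the scatter).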

Compound 4, half-maximal effective concentration: 10 nM
Compound 4: middle estimate off by 11-fold (1.04 log units), on the high side, outside the stated range (below it).
By their numbers in this assay, from the lowest: compound 4; then compounds 3 and 2 (each within the scatter of the next); then compound 1.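

In this assay, the position on the carbonyl carbon proves sensitive: isopropylsulfanyl in place of propoxy gives a 7.9-fold lower number from compound 3 to compound 4 (0.90 log units; beyond the scatter), a step beyond the scatter, even though the two groups match in their counts of heavy atoms, donors and acceptors. Among these compounds, the earlier compounds offered no single-place comparison, so this is the first reading of any change at this position, and it shows that the group here can move the number substantially without any change to the shared core or the aryl group. Nothing measured on these compounds accounts for the step.

The change replaces the oxygen with sulfur and the propyl chain with isopropyl at once, so the compounds shown cannot assign the step to either, and a propylsulfanyl group on the same core would separate the two. Also open, from the compounds shown here alone, is how an amine on this carbonyl carbon, or a longer chain on the sulfur, would compare with isopropylsulfanyl.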